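This account rests on a few compounds, and the source may have more. Where it says the series, first, only, none or still open, it means among the compounds named here.

Measured compounds:
Compound 1 `O=C1N=C(c2ccc(Oc3ccccc3)cc2)S/C1=C\c1ccc(Oc2ccccc2)cc1`: 90 nM
Compound 2 `CCC(=O)Nc1ccc(C2=NC(=O)/C(=C/c3ccc(OC)cc3)S2)cc1`: 760 nM

In an assay on PMNL cells for inhibition of Polyunsaturated fatty acid 5-lipoxygenase (Homo sapiens), read by HPLC, with stated times of 15 min and 10 min (on this read-out higher numbers stand for weaker inhibition and lower numbers for stronger inhibition), compound 1 gives 90 nM, the lowest of the two numbers recorded. Going by the values given here, its nearest neighbour is compound 2, which gives 760 nM in this assay; that gap lies beyond the usual scatter, though no single-point step joins the two compounds, as they differ in more than one place. Compound 3 `O=C1N=C(c2ccc(Cl)cc2)S/C1=C\c1ccc(Oc2ccccc2)cc1` has not yet been measured. It differs from compound 1 by chloro in place of phenoxy on an aromatic carbon: the phenoxy on the aryl attached to the shared core leaves, and a chloro enters at the same aromatic carbon. Among the compounds with values here, no step of this kind has been measured here, so the expected size of the change rests on compound 1 alone. The writer expects compound 3 to be somewhat weaker than compound 1, a step of a 2.2-fold higher number from compound 1 to compound 3 (0.35 log units; beyond the scatter) that may or may not exceed the scatter. Compound 3 is estimated at 200 nM, within a range from 60 nM to 700 nM.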

Compound 3, half-maximal inhibitory concentration: 80 nM
Estimate against measurement, compound 3: 2.5-fold (0.40 log units) above; the range from low to high includes it.
By their numbers in this assay, from the lowest: compounds 3 and 1 (each within the scatter of the next); then compound 2.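

In this assay, chloro in place of phenoxy on this aromatic carbon, para to a large group, gives a 1.1-fold lower number from compound 1 to compound 3 (0.05 log units; within the scatter), so the two compounds cannot be told apart on this read-out. The earlier compounds shown here offered no step at this position; this one shows that the phenoxy, with its six-membered aromatic ring of carbon only, is not needed there for inhibition at this level, at least while the second phenoxy of the shared core stays in place. A single chloro serves as well as the much larger group in this one pair.

Going by these compounds, whether an amine, a carboxylic acid or a longer chain on the same carbon would read alike remains open, as does whether chloro would still match phenoxy with the second phenoxy replaced. The information at hand offers no explanation for why these two groups read alike.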